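A few compounds are considered here, and "the series" means these few. Any claim that something is new, unique, unknown or untested is made for them only; others in the source may bear on it.

Measured so far:
- compound 1, `CC/C=C\COC1(c2ccc(Cl)cc2)SC=C(C)n2c1noc2=O`, gives 55000 nM in a functional assay on A2780 cells (Homo sapiens) for antiproliferative activity, read by MTT assay, with a stated time of 3 days; on this read-out lower numbers stand for stronger inhibition and higher numbers for weaker inhibition
- compound 2, `CC/C=C/COC1(c2ccc(Cl)cc2)SC=C(C)n2c1noc2=O`, gives 55000 nM in this assay

Compound 2 stands level with compound 1 on this assay: the step of no change at the digits printed from compound 1 to compound 2 (within the scatter) shows no change worth noting. The two compounds share every atom and bond, and the only thing separating their drawings is the geometry of the double bond in the side chain, a difference summed up by the fact that one of compounds 1 and 2 is drawn with a defined configuration and the other without, at the place where they differ. That single comparison is all the evidence available here.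

Compound 3, `CCCCOC1(c2ccc(Cl)cc2)SC=C(C)n2c1noc2=O`, is the next structure to consider. It differs from compound 2 by propyl in place of but-1-en-1-yl on a saturated chain carbon bound to an oxygen on a saturated carbon, so the side chain loses its double bond and becomes one carbon shorter. For the measured compounds named here, the only measured step bears on this change merely by showing that redrawing the double bond left the number where it was. Removing the double bond and shortening the chain is a different kind of change, yet nothing measured points to a shift in either direction, so compound 3 is expected to stay close to compound 2, with a step of no change at the digits printed from compound 2 to compound 3 (within the scatter). Compound 3 is therefore estimated at 55000 nM, in the range 20000 nM to 150000 nM.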

Compound 3, half-maximal inhibitory concentration: 89000 nM
The estimate for compound 3 lay 1.6-fold (0.21 log units) below the measured number, within the range that was stated.
By their numbers in this assay, from the lowest: compounds 1, 2 and 3 (each within the scatter of the next).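

Compounds 1 and 2 differ only in how the double bond is drawn, whereas compound 3 changes the chain itself: its propyl group replaces the but-1-en-1-yl group of the other two. In this assay, this change gives a 1.6-fold higher number from compound 2 to compound 3 (0.21 log units; within the scatter) and a 1.6-fold higher number from compound 1 to compound 3 (0.21 log units; within the scatter), which shows that at this position the number stays within the usual spread of repeat measurements even when the double bond is gone and the chain is one carbon shorter, whichever geometry it is compared from. Nothing given here ties a measured property of these chains to this result, and the comparison offers no explanation for it.

Only plain hydrocarbon chains of similar length appear at this position, leaving open whether it would respond to a clearly different group, such as a much longer chain, a benzyl group, an amine or a carboxylic acid. On these data alone, the shared core is also the same in all three compounds, and how much of the activity depends on it remains unknown.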